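The compounds below may be only part of what the source reports. "The series", "measured", "known", "first", "only" and "open" are said of these compounds alone.

Compound 1 `CC(C)(C)c1cc(NC(=O)[C@@H]2CCCCN2C2CCOCC2)no1` gives 74 ug/mL in a physicochemical assay for solubility, read by HPLC, at pH 6.8; a higher number here means a more soluble compound, a lower number a less soluble compound.
Compound 2 `CC(C)(C)c1cc(NC(=O)[C@@H]2CCCCN2CC2CCOCC2)no1` gives 72 ug/mL.
Compound 3 `CC(C)(C)c1cc(NC(=O)[C@@H]2CCCCN2C(=O)N2CCOCC2)no1` gives 45 ug/mL.

Among these three numbers in this assay, compound 2 stands second highest. Its nearest neighbour is compound 1, with a 1.0-fold lower number from compound 1 to compound 2 (0.01 log units; within the scatter), and its furthest is compound 3, with a 1.6-fold lower number from compound 2 to compound 3 (0.20 log units; within the scatter); both of these steps lie within the usual scatter, so the three measured compounds cannot really be told apart on this assay.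

Compound 4 `CC(C)(C)c1cc(NC(=O)[C@@H]2CCCCN2C(=O)N2CC[S+]([O-])CC2)no1` has not yet been measured. Relative to compound 2 the change is a group of 9 heavy atoms (5 carbon, 1 nitrogen, 2 oxygen, 1 sulfur; one six-membered non-aromatic ring with 2 hetero atoms) in place of a group of 7 heavy atoms (6 carbon, 1 oxygen; one six-membered non-aromatic ring with 1 hetero atom), on an amine nitrogen in a ring. The measured steps that bear on this are a 1.6-fold lower number from compound 2 to compound 3 (0.20 log units; within the scatter) and a 1.6-fold lower number from compound 1 to compound 3 (0.22 log units; within the scatter), both within the scatter, and in each a carbonyl-linked ring took the place of a ring attached without a carbonyl on the same nitrogen. Compound 4 carries the same kind of carbonyl link as compound 3, with a different ring behind it. The expected step is therefore small, a 1.4-fold lower number from compound 2 to compound 4 (0.16 log units; within the scatter), and within the scatter. Compound 4 is estimated at 50 ug/mL, with a range from 25 ug/mL to 100 ug/mL.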

Compound 4, solubility: 68 ug/mL
Beside the measured number, compound 4's estimate is 1.4-fold (0.13 log units) below it; low and high end bracket the measured number.
By their numbers in this assay, from the lowest: compounds 3, 4, 2 and 1 (each within the scatter of the next).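

Compound 4 adds a larger group with sulfur in its ring on the same amine nitrogen in a ring, and this assay still gives no readable change, with a 1.1-fold lower number from compound 2 to compound 4 (0.02 log units; within the scatter) and a 1.1-fold lower number from compound 1 to compound 4 (0.04 log units; within the scatter). Changing only the ring behind the carbonyl also stays inside the scatter, with a 1.5-fold higher number from compound 3 to compound 4 (0.18 log units; within the scatter), so all four compounds remain indistinguishable and neither the carbonyl link nor the ring behind it shows a readable effect at this position. No measurement is available here that could explain these numbers.

As far as these compounds go, whether a carboxylic acid or a ring carrying a free amine on this nitrogen would give a step beyond the scatter remains open. From the compounds shown here alone, it is also open whether this flat picture would hold on a changed version of the shared core.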